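The compounds below may be only part of what the source reports. "The series", "measured", "known", "first", "only" and "open" are said of these compounds alone.

Compound 1 `COc1ccc(-c2nc3cc(C(F)(F)F)ccc3[nH]2)c(OC)c1` is the reference point in an ADME assay on MT4 cells (Homo sapiens) for cytotoxicity, read by MTT assay, with a stated time of 96 h; a higher number here means that more compound is tolerated, a lower number that less compound is tolerated. Compound 1 gives > 100000 nM, which is a limit of the assay and not a number. Compound 2 `COc1ccc(-c2nc3cc(C(F)(F)F)ccc3[nH]2)c(OC)c1OC`, which carries one more methoxy, gives 93000 nM in this assay. For the measured compounds named here, the only measured step is an at least 1.0-fold lower number from compound 1 to compound 2 (0.03 log units; that floor lies within the scatter), for methoxy in place of hydrogen on an aromatic carbon.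

Compound 3 `COc1ccc(-c2nc3cc(C(F)(F)F)ccc3[nH]2)c([N+](=O)[O-])c1` has nitro in place of methoxy on an aromatic carbon, ortho to a large group and meta to a methoxy group: nitro in place of methoxy on an aromatic carbon. Going by the values given here, no nitro compound has been measured, so the step to compound 2 bears on this change only loosely. It shows one substitution on the same ring leaving the read-out within the scatter, at an at least 1.0-fold lower number from compound 1 to compound 2 (0.03 log units; that floor lies within the scatter). A small step in this assay is therefore expected, towards a lower number if it shows at all, and a second limit result would be no surprise. The expected step is an at least 1.4-fold lower number from compound 1 to compound 3 (0.15 log units; that floor lies within the scatter). For compound 3 the estimated half-maximal cytotoxic concentration is 70000 nM, with an expected range of 20000 nM to 100000 nM.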

Compound 3, half-maximal cytotoxic concentration: 85000 nM
Estimate against measurement, compound 3: 1.2-fold (0.08 log units) below; the range from low to high includes it.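

In this assay, the carbon ortho to a large group and meta to a methoxy group accepts nitro in place of methoxy, with an at least 1.1-fold lower number from compound 1 to compound 3 (0.07 log units; that floor lies within the scatter). For the compounds shown here, this is the first change that replaces an existing methoxy rather than a hydrogen, and compound 3 gives a measured number, so the tolerated change now extends to a group with different atoms, not only to one more methoxy. For compound 1, the reference value of > 100000 nM is a limit of the assay and not a number, so the step gives only a floor and its true size remains unknown: the limit of > 100000 nM in this assay, at which 1 of the 3 values shown sits.

Still open, going by these compounds, is whether any group on this carbon can move the read-out beyond the scatter, and an amine, a carboxylic acid or a longer chain such as butoxy there would test this in this assay. Also open, on these data alone, is what happens when the trifluoromethyl shared by all three compounds gives way to a hydrogen or a chlorine, or when the other methoxy on the ring gives way to a hydroxyl.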